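Aryl variation on the shared core: outlook for compound 4

The source may hold more compounds than are shown below. What is called first, only, known or untested is meant among the compounds shown, and "the series" means these compounds.

Working notes on the series built on the core of compound 1 `CC/C(=C(/c1ccc(/C=C/C(=O)O)cc1)c1cc2ccccc2[nH]1)c1ccccc1C#N`. In a functional assay on MCF7 cells (Homo sapiens) for inhibition (on this read-out lower numbers stand for stronger inhibition and higher numbers for weaker inhibition), compound 1 gives 9 nM. Compound 2 `CC/C(=C(/c1ccc(/C=C/C(=O)O)cc1)c1cc2ccccc2[nH]1)c1ccc(C#N)cc1` gives 278 nM, and compound 3 `CC/C(=C(/c1ccc(/C=C/C(=O)O)cc1)c1cc2ccccc2[nH]1)c1cccc(Cl)c1Cl` gives 898 nM. Compound 2 therefore stands second highest of the three numbers: the nearest step is a 3.2-fold higher number from compound 2 to compound 3 (0.51 log units; beyond the scatter), the furthest is a 31-fold higher number from compound 1 to compound 2 (1.49 log units; beyond the scatter), both beyond the scatter, with a 100-fold higher number from compound 1 to compound 3 (2.00 log units; beyond the scatter) spanning the full range. Compound 4 `CC/C(=C(/c1ccc(/C=C/C(=O)O)cc1)c1cc2ccccc2[nH]1)c1ccc(Cl)cc1C(F)(F)F` differs from compound 2 by 4-chloro-2-(trifluoromethyl)phenyl in place of 4-cyanophenyl on a double-bonded chain carbon bound to a double-bonded chain carbon and a saturated chain carbon. The entering 4-chloro-2-(trifluoromethyl)phenyl matches neither the 2-cyanophenyl of compound 1 nor the 2,3-dichlorophenyl of compound 3, so the two relevant steps point in opposite directions and only a modest move is expected, a 1.5-fold lower number from compound 2 to compound 4 (0.19 log units; within the scatter). Compound 4 is estimated at 180 nM, between 40 nM and 800 nM.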

Compound 4, half-maximal inhibitory concentration: 4 nM
Compound 4: the middle estimate sits 45-fold (1.65 log units) above what was measured, outside the stated range (below it).
By their numbers in this assay, from the lowest: compound 4; then compound 1; then compound 2; then compound 3.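

In this assay the aryl group on the double-bonded chain carbon need not carry a nitrile: 4-chloro-2-(trifluoromethyl)phenyl gives a 2.3-fold lower number from compound 1 to compound 4 (0.35 log units; beyond the scatter) and so outperforms 2-cyanophenyl. The group also gives a 70-fold lower number from compound 2 to compound 4 (1.84 log units; beyond the scatter) and a 220-fold lower number from compound 3 to compound 4 (2.35 log units; beyond the scatter), which places two chlorine-bearing aryl groups at opposite ends of the series, so chlorine alone does not set the number. No available evidence accounts for these steps.

The compounds shown do not separate the contribution of the chlorine from that of the trifluoromethyl. From the compounds shown here alone, how a methoxy group or an amine on this phenyl would read also remains open.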